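Swapping an aryl group for an aroyl group on the hydrazine

The source may report more compounds than this note shows. Statements on the series, on what has been measured and on what is new or still open speak of the compounds shown alone.

compound 1 `O=C(NNc1cccc(Cl)c1)c1cccc(NS(=O)(=O)c2cnc(O)nc2O)c1` gives 7760 nM
compound 2 `CCCCOc1ccc(C(=O)NNC(=O)c2ccc(NS(=O)(=O)c3cnc(O)nc3O)cc2)cc1` gives 11900 nM
compound 3 `O=C(NNC(=O)c1cccc(Cl)c1)c1ccc(NS(=O)(=O)c2cnc(O)nc2O)cc1` gives 4160 nM

These numbers come from a functional assay on MDA-MB-231 cells (Homo sapiens) for antiproliferative activity, read by MTT assay, with a stated time of 24 h (a lower number here means a stronger inhibitor, a higher number a weaker inhibitor), and belong to three closely related structures. Compound 1 cannot be ranked against the other two, since its value lies within the usual scatter of both compound 2 and compound 3.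

The unmeasured compound 4 `Cc1ccccc1C(=O)NNC(=O)c1cccc(NS(=O)(=O)c2cnc(O)nc2O)c1` differs from compound 1 in one place: (2-methylphenyl)carbonyl in place of 3-chlorophenyl on an amine nitrogen.

Within the data shown here, the one measured step that bears on this is a 2.9-fold lower number from compound 2 to compound 3 (0.46 log units; beyond the scatter) and it is modest. It exchanged 4-butoxyphenyl for 3-chlorophenyl on a carbonyl carbon, so a group swap at such a carbonyl can move the number, but not by much in this one case. Compound 2 and compound 3 also carry a carbonyl at the place where compound 4 gains one, although they differ from compound 4 elsewhere too. Neither value is clearly apart from compound 1 at 7760 nM so no clear shift in either direction is expected.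

The expected change, a 1.1-fold lower number from compound 1 to compound 4 (0.04 log units; within the scatter), should stay within the scatter. For compound 4 the estimated value is 7000 nM with an expected range from 3000 nM to 16000 nM in this assay.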

Compound 4, half-maximal inhibitory concentration: 18100 nM
Beside the measured number, compound 4's estimate is 2.6-fold (0.41 log units) below it; the whole stated range lies below it.
By their numbers in this assay, from the lowest: compounds 3, 1, 2 and 4 (each within the scatter of the next, the first and the last beyond it).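

In this assay the change at this amine nitrogen, (2-methylphenyl)carbonyl in place of 3-chlorophenyl, gives a 2.3-fold higher number from compound 1 to compound 4 (0.37 log units; beyond the scatter) and so makes compound 4 the weaker inhibitor of this pair by a modest margin. The only other step shown, a 2.9-fold lower number from compound 2 to compound 3 (0.46 log units; beyond the scatter), swapped a group on a carbonyl carbon, so this result adds something new: the amine nitrogen is also a place where a swap moves the number beyond the scatter. The swap changes more than one feature at once, since a carbonyl enters the linker while the ring also gains a methyl group and loses its chlorine, and this single step cannot show how much each of these contributes.

On these data alone, it remains open how a smaller acetyl group or a plain benzoyl group on this amine nitrogen would read, and whether (3-chlorophenyl)carbonyl there, which keeps the chlorine of compound 1 while adding the carbonyl, would give a number nearer to that of compound 1 or of compound 4. No measurement in hand explains why the number rose at this position.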